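Cytotoxicity notes: methyl additions on the benzamide ring

This account rests on a few compounds, and the source may have more. Where it says the series, first, only, none or still open, it means among the compounds named here.

Measured compounds:
compound 1 `Cc1cccc(C(=O)Nc2cc(Cl)ccc2OCC(=O)Nc2ccc(S(N)(=O)=O)cc2C)c1`: 52900 nM
compound 2 `Cc1ccc(C(=O)Nc2cc(Cl)ccc2OCC(=O)Nc2ccc(S(N)(=O)=O)cc2C)cc1`: 54200 nM
compound 3 `Cc1ccc(C)c(C(=O)Nc2cc(Cl)ccc2OCC(=O)Nc2ccc(S(N)(=O)=O)cc2C)c1`: 79700 nM

In a functional assay on C8166 cells (Homo sapiens) for cytotoxicity, read by MTT assay (a lower number here means that less compound is tolerated, a higher number that more compound is tolerated), all three numbers lie within the scatter of one another; compound 1 stands within it of compound 2 by a 1.0-fold higher number from compound 1 to compound 2 (0.01 log units; within the scatter) and of compound 3 by a 1.5-fold higher number from compound 1 to compound 3 (0.18 log units; within the scatter). Compound 4 `Cc1cc(C)cc(C(=O)Nc2cc(Cl)ccc2OCC(=O)Nc2ccc(S(N)(=O)=O)cc2C)c1` has not been measured. It differs from compound 1 by methyl in place of hydrogen on an aromatic carbon. Within the data shown here, the one measured step of the same kind, a 1.5-fold higher number from compound 1 to compound 3 (0.18 log units; within the scatter), stayed within the scatter, as did a 1.5-fold higher number from compound 2 to compound 3 (0.17 log units; within the scatter). No step beyond the scatter is therefore expected in this assay, if anything a slightly higher number. Compound 4 is estimated at 65000 nM, with a range of 35000 nM to 120000 nM. The expected step is a 1.2-fold higher number from compound 1 to compound 4 (0.09 log units; within the scatter).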

Compound 4, half-maximal cytotoxic concentration: 36500 nM
For compound 4 the middle estimate is 1.8-fold (0.25 log units) above the measured one, and the stated range covers the measured number.
By their numbers in this assay, from the lowest: compounds 4, 1, 2 and 3 (each within the scatter of the next, the first and the last beyond it).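

In this assay, the 3,5-dimethylphenyl of compound 4 stays within the scatter of both monomethyl compounds (a 1.4-fold lower number from compound 1 to compound 4 (0.16 log units; within the scatter); a 1.5-fold lower number from compound 2 to compound 4 (0.17 log units; within the scatter)). Among these compounds, the only step here beyond the scatter separates the two dimethylphenyl isomers (a 2.2-fold lower number from compound 3 to compound 4 (0.34 log units; beyond the scatter)), so the placement of the second methyl matters more on this ring than its presence, though the gap is modest. No available data explain this gap.

From the compounds shown here alone, whether this placement effect extends to groups other than methyl, such as methoxy, chlorine or an amine, remains open. Also open, going by these compounds, is whether it would appear with a longer chain such as ethyl.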